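Chloro for Fluoro on the Shared Core

The compounds below may be only part of what the source reports. "The series", "measured", "known", "first", "only" and "open" are said of these compounds alone.

Measured so far:
Compound 1, `O=C(O)Cn1nc(Cc2nc3cc(Cl)c(OCC(F)F)cc3[nH]2)c2ccccc2c1=O`: < 56.7 mL/min/kg
Compound 2, `O=C(O)Cn1nc(Cc2nc3cc(F)c(OCC4CC4)cc3[nH]2)c2ccccc2c1=O`: < 53.4 mL/min/kg

In an ADME assay on microsomes from liver (Mus musculus) for metabolic stability (a higher number here means faster removal of the compound, a lower number slower removal), compound 2 gives < 53.4 mL/min/kg, which is a limit of the assay rather than a number. Compound 1 gives < 56.7 mL/min/kg, also a limit. Both shown values thus sit at limits (the limit of < 53.4 mL/min/kg in this assay, at which 1 of the 2 values shown sits, (the limit of < 56.7 mL/min/kg in this assay, at which 1 of the 2 values shown sits)), so nothing places compound 2 above or below compound 1.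

Compound 3, `O=C(O)Cn1nc(Cc2nc3cc(Cl)c(OCC4CC4)cc3[nH]2)c2ccccc2c1=O`, differs from compound 2 by chloro in place of fluoro on an aromatic carbon. Going by the values given here, no step between measured compounds exists to lean on. The step that the limit leaves unreadable from compound 2 to compound 3 is expected to be small, within the scatter. Compound 3 is estimated at 35 mL/min/kg, ranging from 12 mL/min/kg to 85 mL/min/kg.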

Compound 3, clearance in the Mus musculus assay: 147 mL/min/kg
Compound 3: the middle estimate sits 4.2-fold (0.62 log units) below what was measured; the whole stated range lies below it.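

In the Mus musculus assay, chloro in place of fluoro on this aromatic carbon, ortho to the cyclopropylmethoxy group, gives an at least 2.7-fold higher number from compound 2 to compound 3 (0.43 log units; beyond the scatter), and cyclopropyl in place of difluoromethyl on the chain gives an at least 2.5-fold higher number from compound 1 to compound 3 (0.41 log units; beyond the scatter). Each step starts from a limit of the assay, so each gives only a minimum size. In a physicochemical assay for solubility, measured as thermodynamic solubility, at pH 7.4 (on this read-out lower numbers stand for lower solubility and higher numbers for higher solubility), compound 2 gives 841 ug/mL and compound 3 gives 395 ug/mL, which is a 2.1-fold lower number from compound 2 to compound 3 (0.33 log units; beyond the scatter).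

As far as these compounds go, what a nitrile or a methyl on this aromatic carbon would do to either read-out stays open.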